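The source may report more compounds than this note shows. Statements on the series, on what has been measured and on what is new or still open speak of the compounds shown alone.

In a functional assay on QGY7701 cells (Homo sapiens) for cytotoxicity, read by MTT assay, with a stated time of 24 h (on this read-out lower numbers stand for stronger inhibition and higher numbers for weaker inhibition), compound 2 `C=CC1=C(C(=O)O)C(c2ccc(OC)cc2)OC1` gives > 100000 nM, which is a limit of the assay and not a number. Compound 1 `C=CC1=C(C(=O)O)C(c2ccc(F)cc2)OC1` likewise gives > 100000 nM, also a limit. The step that the two limits leave unreadable from compound 1 to compound 2 is therefore not readable, and the limit of > 100000 nM in this assay, at which 2 of the 3 values shown sit, shows where both of these values sit. Compound 3 `C=CC1=C(C(=O)NC2CCCCC2)C(c2ccc(OC)c(OC)c2)OC1` gives 7490 nM. Compound 4 `C=CC1=C(C(=O)Nc2ccccc2)C(c2ccc(OC)cc2)OC1` differs from compound 2 by anilino in place of hydroxy on a carbonyl carbon. Within the data shown here, no measured step replaces the hydroxy on the carbonyl carbon while the aryl group is held fixed, so the size of this step is not known from the data. Compound 3 shows only that such a substitution on the carbonyl carbon can give a number within this assay. Compound 4 is therefore estimated at 15000 nM, between 3000 nM and 100000 nM. That estimate means an expected step of an at least 6.6-fold lower number from compound 2 to compound 4 (0.82 log units; beyond the scatter) toward stronger inhibition, though its size remains uncertain.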

Compound 4, half-maximal inhibitory concentration: > 100000 nM
Compound 4 was reported as a limit; the forecaster's own chance of this, stated with the estimate: 30%; middle value at least 6.6-fold (0.82 log units) from the limit.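

Among these compounds, compound 4 gives > 100000 nM, a limit and not a number; compound 2 also sits at a limit, so no step between them can be read. The compounds shown leave open what anilino in place of hydroxy on the carbonyl carbon does in this assay.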